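Trimming the amide chain to a vinyl group

The compounds below may be only part of what the source reports. "The series", "measured", "known", "first", "only" and "open" are said of these compounds alone.

Of the compounds shown here, three sharing one core have been measured in a functional assay on HCT-116 cells (Homo sapiens) for inhibition, read by MTT assay, with a stated time of 48 h; a higher number here means a weaker inhibitor, a lower number a stronger inhibitor. Compound 1 `CCC/C=C/C(=O)N(Cc1ccc(OC)c(O)c1)c1cc(OC)c(OC)c(OC)c1` gives 95 nM, compound 2 `COc1ccc(CN(C(=O)CCCl)c2cc(OC)c(OC)c(OC)c2)cc1O` gives 150 nM, and compound 3 `CCCCC(=O)N(Cc1ccc(OC)c(O)c1)c1cc(OC)c(OC)c(OC)c1` gives 170 nM. Compound 3 carries the highest of the three numbers, yet every gap to it is within the scatter: compound 2 sits nearest, as a 1.1-fold higher number from compound 2 to compound 3 (0.05 log units; within the scatter) shows, and compound 1 furthest, as a 1.8-fold higher number from compound 1 to compound 3 (0.25 log units; within the scatter) shows. Compound 4 `C=CC(=O)N(Cc1ccc(OC)c(O)c1)c1cc(OC)c(OC)c(OC)c1` is not yet measured. It differs from compound 3 in one place: vinyl in place of butyl on a carbonyl carbon.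

Among the measured compounds shown here, two measured steps bear on this change. The step of a 1.8-fold higher number from compound 1 to compound 3 (0.25 log units; within the scatter) exchanges an unsaturated chain on the carbonyl carbon for a saturated one and stays within the scatter. The step of a 1.1-fold higher number from compound 2 to compound 3 (0.05 log units; within the scatter) alters the same chain in another way and also stays within the scatter. The change in compound 4 again concerns only the chain on the carbonyl carbon, now a vinyl group. Nothing among the three compounds suggests a step beyond the scatter, so compound 4 is expected to give a number close to compound 3, perhaps slightly lower as compound 1 hints. The estimated step is a 1.4-fold lower number from compound 3 to compound 4 (0.15 log units; within the scatter). For compound 4 the estimate is 120 nM, in the range 50 nM to 300 nM.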

Compound 4, half-maximal inhibitory concentration: 98 nM
Beside the measured number, compound 4's estimate is 1.2-fold (0.09 log units) above it; measured number inside the range.
By their numbers in this assay, from the lowest: compounds 1, 4, 2 and 3 (each within the scatter of the next).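

Compound 4 carries vinyl, of 2 heavy atoms, as the chain on the carbonyl carbon. The change from butyl, of 4 heavy atoms, stays within the scatter in this assay (a 1.7-fold lower number from compound 3 to compound 4 (0.24 log units; within the scatter)). Among the compounds shown here, the other two chains give the same picture (a 1.5-fold lower number from compound 2 to compound 4 (0.18 log units; within the scatter); a 1.0-fold higher number from compound 1 to compound 4 (0.01 log units; within the scatter)), so across these four compounds this position takes pent-1-en-1-yl, 2-chloroethyl, butyl and vinyl with no step beyond the scatter, and the change in heavy atom count from butyl to vinyl brings no step that can be told apart from repeat measurement. No measured evidence is available here to explain why the four values stay so close together.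

The compounds shown leave open whether the double bond or the chain length matters at all, since a plain ethyl group on the carbonyl carbon would separate the two, and whether a much longer chain, an amine or a carboxylic acid at this position would produce a step beyond the scatter. They also say nothing about changes elsewhere on the shared core, which stays the same throughout, so the tolerance seen here applies only to the chain on the carbonyl carbon.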